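A Trifluoroethyl Carbamate Faces the Cytotoxicity Test

A few compounds are considered here, and "the series" means these few. Any claim that something is new, unique, unknown or untested is made for them only; others in the source may bear on it.

Compound 1 `CCCOCC(=O)Nc1cc2nc(C3CCCCC3)[nH]c2cc1N1CCCC1` and compound 2 `CCOCCOC(=O)Nc1cc2nc(C3CCCCC3)[nH]c2cc1N1CCCC1` share one core and differ only in the group on a carbonyl carbon. In an ADME assay on Vero cells (Chlorocebus sabaeus) for cytotoxicity, read by resazurin assay, with a stated time of 3 days (a lower number here means a stronger inhibitor, a higher number a weaker inhibitor), compound 1 gives only a limit, > 100 ug/mL. In this assay compound 2 likewise gives only a limit, > 100 ug/mL. The step that the two limits leave unreadable from compound 1 to compound 2 therefore cannot be read, and the limit of > 100 ug/mL in this assay, at which 2 of the 2 values shown sit, is the whole of the evidence. Compound 3 `O=C(Nc1cc2nc(C3CCCCC3)[nH]c2cc1N1CCCC1)OCC(F)(F)F` carries trifluoromethyl in place of ethoxymethyl on a saturated chain carbon bound to an oxygen next to a carbonyl group. With no readable step to lean on, compound 3 is expected to sit at the limit too, estimated at 120 ug/mL within 60 ug/mL to 300 ug/mL. The expected step that the limit leaves unreadable from compound 2 to compound 3 is thus none beyond the scatter.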

Compound 3, half-maximal inhibitory concentration: > 100 ug/mL
Compound 3 gave a limit, no number (the forecaster's own chance of this, stated with the estimate: 80%); the middle value lies beyond the limit too.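

Compound 1, compound 2 and compound 3 all give only a limit in this assay, so no step among them can be read: the limit of > 100 ug/mL in this assay, at which 3 of the 3 values shown sit.

On these data alone, how far each compound lies past that limit, and whether the group on the carbonyl carbon changes the value at all, stays open.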